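The source may report more compounds than this note shows. Statements on the series, on what has been measured and on what is new or still open speak of the compounds shown alone.

Compound 1 `COc1cc2c(Oc3ccc(NC(=O)N/N=C/c4ccc(Cl)cc4Cl)cc3F)ccnc2cc1OCCCN1CCCCC1` gives 370 nM in a functional assay on HT-29 cells (Homo sapiens) for cytotoxicity, read by MTT assay, with a stated time of 72 h; on this read-out higher numbers stand for weaker inhibition and lower numbers for stronger inhibition.
Compound 2 `COc1cc2c(Oc3ccc(NC(=O)N/N=C/c4ccc(OC(F)(F)F)cc4)cc3F)ccnc2cc1OCCCN1CCCCC1` gives 510 nM in this assay.
Compound 3 `COc1cc2c(Oc3ccc(NC(=O)N/N=C/c4ccc(O)cc4)cc3F)ccnc2cc1OCCCN1CCCCC1` gives 470 nM in this assay.

On these numbers compound 3 sits between the other two, and all three values lie within the usual scatter of one another. Compound 4 `COc1cc2c(Oc3ccc(NC(=O)N/N=C/c4cccs4)cc3F)ccnc2cc1OCCCN1CCCCC1` differs from compound 3 in one place: thiophen-2-yl in place of 4-hydroxyphenyl on a carbon with a double bond to nitrogen. Among the compounds with values here, three measured steps bear on this position, each swapping the group on the carbon double-bonded to nitrogen: a 1.3-fold higher number from compound 1 to compound 3 (0.10 log units; within the scatter), a 1.1-fold lower number from compound 2 to compound 3 (0.04 log units; within the scatter) and a 1.4-fold higher number from compound 1 to compound 2 (0.14 log units; within the scatter). Every one of them stays within the scatter, so no step beyond the scatter is expected in this assay; the expected step is no change at the digits printed from compound 3 to compound 4 (within the scatter). Compound 4 is therefore estimated to give 470 nM in this assay, with an expected range from 200 nM to 1100 nM.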

Compound 4, half-maximal inhibitory concentration: 770 nM
Compound 4: the middle estimate sits 1.6-fold (0.21 log units) below what was measured, within the range that was stated.
By their numbers in this assay, from the lowest: compounds 1, 3, 2 and 4 (each within the scatter of the next, the first and the last beyond it).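

Thiophen-2-yl in place of 4-hydroxyphenyl stays within the scatter in this assay (a 1.6-fold higher number from compound 3 to compound 4 (0.21 log units; within the scatter)), as does thiophen-2-yl in place of 4-(trifluoromethoxy)phenyl (a 1.5-fold higher number from compound 2 to compound 4 (0.18 log units; within the scatter)). Thiophen-2-yl in place of 2,4-dichlorophenyl gives the first step at this position that passes beyond the scatter, though only modestly (a 2.1-fold higher number from compound 1 to compound 4 (0.32 log units; beyond the scatter)). Nothing available explains this step.

Still open, as far as these compounds go, is how a non-aromatic group on this carbon, such as a cyclohexyl ring, would compare. Also open, from the compounds shown here alone, is whether a phenyl ring carrying a dimethylamino group or a carboxylic acid would stay within the scatter.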